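This account rests on a few compounds, and the source may have more. Where it says the series, first, only, none or still open, it means among the compounds named here.

The measured compounds:

Compound 1, `CCn1cc(-c2nc3ccccc3[nH]2)c(=O)c2cc(F)c(N3CCNCC3)nc21`: in a functional assay on KB cells (Homo sapiens) for cytotoxicity, read by MTT assay, with a stated time of 48 h (a higher number here means a weaker inhibitor, a lower number a stronger inhibitor), compound 1 gives 2000 nM.

Compound 2, `CCn1cc(-c2nc3ccccc3[nH]2)c(=O)c2cc(F)c(N3CCNC(C)C3)c(F)c21`: in this assay compound 2 gives 19100 nM.

Compound 3, `CCn1cc(-c2nc3ccccc3o2)c(=O)c2cc(F)c(N3CCNC(C)C3)c(F)c21`: in this assay compound 3 gives 18900 nM.

Compound 2 and compound 3 share one core and differ in a single place:

1,3-benzoxazol-2-yl in place of 1H-benzimidazol-2-yl on an aromatic carbon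

That exchange produced a 1.0-fold lower number from compound 2 to compound 3 (0.00 log units; within the scatter), so the two compounds are indistinguishable within the usual scatter of this measurement. Compound 1 is built on a different core from compound 2 and compound 3; the difference between the two cores is not broken down here. Among the three measured compounds, compound 1 gives the lowest number in this assay, and its gaps to compound 2 and to compound 3 both lie beyond the scatter.

Compound 4, `CCn1cc(-c2nc3ccccc3o2)c(=O)c2cc(F)c(N3CCNCC3)nc21`, has not been measured. It differs from compound 1 in one place:

1,3-benzoxazol-2-yl in place of 1H-benzimidazol-2-yl on an aromatic carbon

Among the measured compounds shown here, this is the same change as the one from compound 2 to compound 3, made at a place described in identical words. For the measured compounds named here, the only guide is that earlier step, which was a 1.0-fold lower number from compound 2 to compound 3 (0.00 log units; within the scatter). Compound 4 is therefore expected to show a 1.1-fold higher number from compound 1 to compound 4 (0.04 log units; within the scatter), because the same exchange between compound 2 and compound 3 gave a 1.0-fold lower number from compound 2 to compound 3 (0.00 log units; within the scatter). For compound 4 the estimated value in this assay is 2200 nM, with a likely range from 1000 nM to 5000 nM.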

Compound 4, half-maximal inhibitory concentration: 11700 nM
Compound 4: the middle estimate sits 5.3-fold (0.73 log units) below what was measured; measured number above the stated range.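

Swapping 1H-benzimidazol-2-yl for 1,3-benzoxazol-2-yl had a clear effect on the core of compound 1: in this assay, the swap gave a 5.9-fold higher number from compound 1 to compound 4 (0.77 log units; beyond the scatter). The result of this change therefore did not carry over unchanged from one core to the other, as setting the two steps side by side shows: the same change on two cores in this assay, a 1.0-fold lower number (0.00 log units; within the scatter) from compound 2 to compound 3 and a 5.9-fold higher number (0.77 log units; beyond the scatter) from compound 1 to compound 4, 5.9-fold (0.77 log units) apart, beyond the scatter of two such steps This does not show why the two cores respond differently, or which part of them matters, because compound 1 and compound 2 differ in more than one place; nor does one pair on each core show how the exchange would behave on any further core, so a step measured on one core in this series is only a weak guide to the same step on another.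

From the compounds shown here alone, it remains open what a 1,3-benzothiazol-2-yl group, which has sulfur where the benzoxazole has oxygen, or a simple carboxylic acid would give on the same aromatic carbon of either core. Also open, going by these compounds, is whether the gap between the two steps would persist if the cores were altered one place at a time, for example by adding only a methyl group to the core of compound 1.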